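A Methyl Added to the Triazole-Linked Phenyl Ring

The source may report more compounds than this note shows. Statements on the series, on what has been measured and on what is new or still open speak of the compounds shown alone.

Of the compounds shown here, two have been measured in a functional assay on HL-60 cells (Homo sapiens) for cytotoxicity, read by MTT assay, with a stated time of 4 days; a higher number here means a weaker inhibitor, a lower number a stronger inhibitor. Compound 1 `C=C1C[C@]23C[C@@]1(O)CC[C@H]2c1ccc(OS(=O)(=O)c2ccc(C)cc2)c(C)c1[C@@H]3Cn1cc(-c2ccc(C)cc2)nn1` gives > 20000 nM in this assay, which is a limit of the assay rather than a number. Compound 2 `C=C1C[C@]23C[C@@]1(O)CC[C@H]2c1ccc(O)c(C)c1[C@@H]3Cn1cc(-c2ccccc2)nn1` likewise gives > 20000 nM in this assay, again a limit and not a measured number. For the measured compounds named here, compound 1 and compound 2 differ from each other in more than one place, so no single step between them can be read. Where compound 2 stands is therefore only this: the limit of > 20000 nM in this assay, at which 2 of the 2 values shown sit, and nothing finer is known.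

Compound 3 `C=C1C[C@]23C[C@@]1(O)CC[C@H]2c1ccc(O)c(C)c1[C@@H]3Cn1cc(-c2ccc(C)cc2)nn1` is the next compound. The change from compound 2 to compound 3 is methyl in place of hydrogen on an aromatic carbon, a methyl in place of hydrogen on an aromatic carbon. Going by the values given here, no measured pair shows what such a change does here. Since compound 2 sits at the limit, the step is expected to be small, with no clear direction beyond the scatter, so that a step that the limit leaves unreadable from compound 2 to compound 3 is expected. Compound 3 is estimated to give 30000 nM in this assay, within a range from 8000 nM to 100000 nM, and most likely it will again be reported only as a limit.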

Compound 3, half-maximal inhibitory concentration: > 20000 nM
Compound 3: a limit, no number (the forecaster's own chance of this, stated with the estimate: 85%); the middle value does not contradict the limit.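

Neither the step from compound 2 to compound 3 nor the step from compound 1 to compound 3 can be read, since all three compounds end at the same limit: the limit of > 20000 nM in this assay, at which 3 of the 3 values shown sit.

The compounds shown leave open whether methyl in place of hydrogen, or (4-methylphenyl)sulfonyl in place of hydrogen on the oxygen, changes the result in this assay at all.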